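This account rests on a few compounds, and the source may have more. Where it says the series, first, only, none or still open, it means among the compounds named here.

Compound 1 `c1ccc(-c2cccc3c2CCC3c2ncc[nH]2)nc1`: 1150 nM
Compound 2 `COc1cccc2c1CCC2c1ncc[nH]1`: 32 nM

Both compounds were measured in a functional assay on CHO cells for agonist activity at Alpha-1A adrenergic receptor (Homo sapiens), read by FLIPR and calcium flux; on this read-out higher numbers stand for an effect only at larger amounts of compound and lower numbers for an effect already at smaller amounts. For the measured compounds named here, of the two numbers, compound 1 holds the highest; its only neighbour is compound 2, reached by the step of a 36-fold lower number from compound 1 to compound 2 (1.56 log units; beyond the scatter), a change at one aromatic carbon of the shared core. Compound 3 `c1ccc2c(c1)CCC2c1ncc[nH]1` has not yet been measured. It differs from compound 1 in a single place: hydrogen in place of pyridin-2-yl on an aromatic carbon. Going by the values given here, the one measured step that touches this position is a 36-fold lower number from compound 1 to compound 2 (1.56 log units; beyond the scatter), in which the pyridin-2-yl also left, though a methoxy entered rather than a hydrogen. That step is large and beyond the scatter, so for compound 3 a step toward a lower number is expected, a 12-fold lower number from compound 1 to compound 3 (1.06 log units; beyond the scatter), probably smaller than the measured one since a hydrogen, not a methoxy, now takes the place. In this assay compound 3 is estimated at 100 nM, within a range of 25 nM to 500 nM.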

Compound 3, half-maximal effective concentration: 473 nM
Compound 3: middle estimate off by 4.7-fold (0.67 log units), on the low side; the range from low to high includes it.
By their numbers in this assay, from the lowest: compound 2; then compound 3; then compound 1.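

Replacing the pyridin-2-yl with plain hydrogen on this aromatic carbon gives only a modest change in this assay, a 2.4-fold lower number from compound 1 to compound 3 (0.39 log units; beyond the scatter), so hydrogen does not reproduce the low number seen with methoxy. The large step here is the one for methoxy, a 15-fold higher number from compound 2 to compound 3 (1.17 log units; beyond the scatter), which shows that, measured against hydrogen, methoxy is the group that brings the number down sharply, while pyridin-2-yl moves it up only modestly. No measurement on hand explains why these groups differ in this way.

Going by these compounds, it remains open whether the low number is particular to methoxy or is shared by other small groups on this carbon, such as ethoxy, hydroxy, fluorine or an amine. The compounds shown also do not tell whether methoxy would have the same effect on another aromatic carbon of the shared core.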